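This account rests on a few compounds, and the source may have more. Where it says the series, first, only, none or still open, it means among the compounds named here.

Within the data shown here, compound 1 `CC(=O)N1CC(Oc2cc(-c3cnnc4c3ncn4C(C)C)ccc2F)C1` stands lowest of the two compounds measured so far. In a physicochemical assay for lipophilicity (a lower number here means a more polar compound, a higher number a more lipophilic compound), compound 1 gives 1.6, while compound 2 `CCn1cnc2c(-c3ccc(F)c(Oc4cnc(C#N)nc4)c3)cnnc21` gives 2 in this assay, a gap that lies beyond the scatter of such measurements. The next compound, compound 3 `Cc1cc(-c2cc(-c3cnnc4c3ncn4C(C)C)ccc2F)ccn1`, has not yet been measured. Its structure follows from compound 1 by a single change: 2-methylpyridin-4-yl in place of (1-acetylazetidin-3-yl)oxy on an aromatic carbon. A four-membered non-aromatic ring with one hetero atom and two hydrogen-bond acceptors leaves, and a six-membered aromatic ring with one hetero atom and one hydrogen-bond acceptor enters, ortho to the fluoro group. Among the measured compounds shown here, no measured pair shows this change, so its size can only be estimated. Compound 3 is expected to read higher than compound 1 in this assay, by an estimated step of a number 1.10 log units higher from compound 1 to compound 3 (beyond the scatter), beyond the scatter. The estimate for compound 3 in this assay is 2.7, expected to fall between 2.1 and 3.3.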

Compound 3, distribution coefficient: 3.1
The estimate for compound 3 lay 0.40 log units below the measured number; low and high end bracket the measured number.
By their numbers in this assay, from the lowest: compound 1; then compound 2; then compound 3.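

On an aromatic carbon ortho to a fluoro group, putting 2-methylpyridin-4-yl in place of (1-acetylazetidin-3-yl)oxy gives a large step in this assay, a number 1.50 log units higher from compound 1 to compound 3 (beyond the scatter), and this is the first pair shown that differs in one place. With the rest of the structure unchanged, the group at this position alone moves the reading by this much, so the position is not silent in this read-out. Nothing at hand indicates which part of the exchange accounts for the step.

The compounds shown leave open how the step divides among the ether oxygen, the acetyl group and the ring itself. They also leave open whether an unsubstituted pyridin-4-yl or a morpholine at this place would read closer to compound 1 or to compound 3.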